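This account rests on a few compounds, and the source may have more. Where it says the series, first, only, none or still open, it means among the compounds named here.

Compound 1 `CCCCCCCCCCn1cc(Cn2nc(N)c3c(C(F)(F)F)cc(-c4ccccc4)nc32)nn1`: 48.7 ug/mL
Compound 2 `Nc1nn(Cc2cn(-c3ccc(O)c([N+](=O)[O-])c3)nn2)c2nc(-c3ccccc3)cc(C(F)(F)F)c12`: 36.3 ug/mL

Both values come from a functional assay on THP-1 cells (Homo sapiens) for cytotoxicity, read by MTT assay, with a stated time of 24 h; on this read-out lower numbers stand for stronger inhibition and higher numbers for weaker inhibition. On these two numbers, compound 2 cannot be told apart from compound 1, since the gap between them lies within the scatter. Compound 3 `COc1ccc(NC(=O)Cn2cc(Cn3nc(N)c4c(C(F)(F)F)cc(-c5ccccc5)nc43)nn2)cc1`, not yet measured, keeps the shared core and differs from compound 2 in one group: ((4-methoxyphenyl)carbamoyl)methyl in place of 4-hydroxy-3-nitrophenyl on an aromatic nitrogen. In words, ((4-methoxyphenyl)carbamoyl)methyl takes the place of 4-hydroxy-3-nitrophenyl on an aromatic nitrogen. Within the data shown here, one measured step touches that same nitrogen: putting 4-hydroxy-3-nitrophenyl in place of decyl gave a 1.3-fold lower number from compound 1 to compound 2 (0.13 log units; within the scatter). This is a single step, but it shows two quite unlike groups there giving numbers within the scatter. No step beyond the scatter is therefore expected in this assay, and neither direction is favoured. The estimated step is a 1.1-fold higher number from compound 2 to compound 3 (0.04 log units; within the scatter). For compound 3 the expected value is 40 ug/mL, with a likely range from 19 ug/mL to 85 ug/mL.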

Compound 3, half-maximal inhibitory concentration: 56.7 ug/mL
Compound 3: the middle estimate sits 1.4-fold (0.15 log units) below what was measured, within the range that was stated.
By their numbers in this assay, from the lowest: compounds 2, 1 and 3 (each within the scatter of the next).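

In this assay, a third quite unlike group on the same aromatic nitrogen again leaves the numbers within the scatter: ((4-methoxyphenyl)carbamoyl)methyl gives a 1.6-fold higher number from compound 2 to compound 3 (0.19 log units; within the scatter) and, set against the decyl chain, a 1.2-fold higher number from compound 1 to compound 3 (0.07 log units; within the scatter). Among these compounds, the single earlier step now has company, as a plain saturated chain, a ring bound directly to the nitrogen and a ring carried on a carbamoylmethyl link all give numbers that cannot be told apart in this cell assay. Nothing measured here speaks to why these numbers stay so close.

On these data alone, whether a group of another kind on this nitrogen, such as an amine or a carboxylic acid, would produce a step beyond the scatter remains open. As far as these compounds go, all three compounds also share the same core, so the effect of a change elsewhere is unknown.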